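The source may hold more compounds than are shown below. What is called first, only, known or untested is meant among the compounds shown, and "the series" means these compounds.

In an ADME assay on Huh-7 cells (Homo sapiens) for cytotoxicity (on this read-out higher numbers stand for lower toxicity in this test and lower numbers for higher toxicity in this test), compound 1 `C[C@@]1(O)[C@H](O)[C@@H](CO)O[C@H]1c1ccc2c(N)ncnn12` gives > 100000 nM, which is a limit of the assay and not a number. Going by the values given here, compound 2 `C[C@@]1(O)[C@H](O)[C@@H](CO)O[C@H]1c1cc(Cl)c2c(N)ncnn12` gives 6500 nM, the only actual number so far. Among the compounds with values here, the one measured step is large: an at least 15-fold lower number from compound 1 to compound 2 (1.18 log units; beyond the scatter). Compound 3 `C[C@@]1(O)[C@H](O)[C@@H](CO)O[C@H]1c1cc(-c2ncc[nH]2)c2c(N)ncnn12` keeps the shared core and changes that same carbon again, with 1H-imidazol-2-yl in place of chloro on an aromatic carbon. Chloro leaves here, and its arrival in the measured step of an at least 15-fold lower number from compound 1 to compound 2 (1.18 log units; beyond the scatter) went with a large drop, so some move back towards higher numbers seems likely. However, the entering group is not hydrogen, and no measurement yet covers it, so a smaller rise than that drop is the cautious expectation. In this assay, the expected change is a 3.1-fold higher number from compound 2 to compound 3 (0.49 log units; beyond the scatter). Compound 3 is estimated at 20000 nM, with an expected range from 4000 nM to 90000 nM.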

Compound 3, half-maximal cytotoxic concentration: 27100 nM
The estimate for compound 3 lay 1.4-fold (0.13 log units) below the measured number; the measured number falls inside the stated range.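

Replacing chloro with 1H-imidazol-2-yl at this aromatic carbon gives a 4.2-fold higher number from compound 2 to compound 3 (0.62 log units; beyond the scatter) in this assay, so the number here depends on which group is present, and the larger group does not give the lower number. Compared with hydrogen, 1H-imidazol-2-yl still gives an at least 3.6-fold lower number from compound 1 to compound 3 (0.56 log units; beyond the scatter), which means that both groups tested at this carbon lower the number, though to different degrees. Compound 1 stands at a limit and not a number, so the full size of that last step cannot be read: the limit of > 100000 nM in this assay, at which 1 of the 3 values shown sits.

The compounds shown carry only hydrogen, chloro and 1H-imidazol-2-yl at this carbon, so they cannot separate the effect of the ring from that of its nitrogen atoms. As far as these compounds go, whether an amine, a methyl group or a phenyl ring here would give numbers closer to compound 1 or compound 2 remains open.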